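This account rests on a few compounds, and the source may have more. Where it says the series, first, only, none or still open, it means among the compounds named here.

Compound 1 `Cc1oc2c([C@H]3CCN(C)C[C@H]3O)c(O)cc(O)c2c(=O)c1C(O)c1ccc(F)c(Br)c1`: 6%
Compound 2 `Cc1oc2c([C@H]3CCN(C)C[C@H]3O)c(O)cc(O)c2c(=O)c1C(O)c1cc(F)cc(F)c1`: 10%

Only these two compounds have been measured so far, both in a functional assay on Caco-2 cells (Homo sapiens) for inhibition, read by MTT assay, with a stated time of 48 h, tested at 10 uM; on this read-out higher numbers stand for more inhibition of growth at the one concentration tested and lower numbers for less inhibition of growth. There, compound 2 gives 10% and compound 1 gives 6%, so the two stand within the scatter of each other and both show little inhibition of growth. The next compound to be tested is compound 3 `CCOc1ccc(Br)c(C(O)c2c(C)oc3c([C@H]4CCN(C)C[C@H]4O)c(O)cc(O)c3c2=O)c1`, which keeps the shared core of compound 2 and changes one group, on a saturated chain carbon bound to an aromatic carbon and an oxygen on a saturated carbon: 2-bromo-5-ethoxyphenyl in place of 3,5-difluorophenyl on a saturated chain carbon bound to an aromatic carbon and an oxygen on a saturated carbon.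

For the measured compounds named here, one measured step bears on this place, a number 4 percentage points higher from compound 1 to compound 2 (within the scatter). Going by the values given here, no measured compound carries the 2-bromo-5-ethoxyphenyl group, so the evidence is thin. Among the compounds with values here, a step beyond the scatter in this assay is not expected, because a number 4 percentage points higher from compound 1 to compound 2 (within the scatter) is the only change seen at this place. The expected step is a number 1 percentage points higher from compound 2 to compound 3 (within the scatter). The estimated value for compound 3 is 11%, within an expected range of 2% to 24%.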

Compound 3, percent growth inhibition at one concentration: 5%
Estimate against measurement, compound 3: 6 percentage points above, within the range that was stated.
By their numbers in this assay, from the lowest: compounds 3, 1 and 2 (each within the scatter of the next).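

In this assay the 2-bromo-5-ethoxyphenyl group gives a number 5 percentage points lower from compound 2 to compound 3 (within the scatter) when it replaces 3,5-difluorophenyl, and a number 1 percentage points lower from compound 1 to compound 3 (within the scatter) when it replaces 3-bromo-4-fluorophenyl. A third substituted phenyl group at this place, on a saturated chain carbon bound to an aromatic carbon and an oxygen on a saturated carbon, therefore reads within the scatter of both earlier compounds, even though it adds an ethoxy chain and a hydrogen-bond acceptor that 3,5-difluorophenyl lacks, and all three compounds show little inhibition of growth at the one concentration tested. Nothing measured here accounts for the three readings staying so close together.

Going by these compounds, it remains open whether a group of another kind at this place, such as a pyridine ring, a carboxylic acid or an aminomethyl group on the phenyl ring, would give a number beyond the scatter of these three. Also open, on these data alone, is whether a longer chain such as butoxy in place of ethoxy would stand apart from them.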